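Para-Substituent Swap on the Benzyl Triazole: Chloro to Methoxy

The source may hold more compounds than are shown below. What is called first, only, known or untested is meant among the compounds shown, and "the series" means these compounds.

Compound 1, `COc1ccc(-c2nn(-c3ccccc3)cc2C(=O)NCc2cn(Cc3ccc(F)cc3)nn2)cc1`, gives 24100 nM in a functional assay on MIA PaCa-2 cells (Homo sapiens) for antiproliferative activity, read by sulforhodamine B assay, with a stated time of 48 h; on this read-out lower numbers stand for stronger inhibition of growth and higher numbers for weaker inhibition of growth.
Compound 2, `COc1ccc(-c2nn(-c3ccccc3)cc2C(=O)NCc2cn(Cc3ccc(Cl)cc3)nn2)cc1`, gives 26300 nM in this assay.

For the measured compounds named here, only two compounds have been measured, and compound 2 stands within the scatter of compound 1: the step of a 1.1-fold higher number from compound 1 to compound 2 (0.04 log units; within the scatter) shows that exchanging one halogen for another at this position left the growth-inhibition number essentially unchanged.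

Compound 3, `COc1ccc(Cn2cc(CNC(=O)c3cn(-c4ccccc4)nc3-c3ccc(OC)cc3)nn2)cc1`, is not yet measured. It differs from compound 2 in one place: methoxy in place of chloro on an aromatic carbon.

Going by the values given here, the only measured step that bears on this change is a 1.1-fold higher number from compound 1 to compound 2 (0.04 log units; within the scatter), which concerned the same aromatic carbon of the same ring and lay within the scatter. Among the compounds with values here, that step swapped one halogen for another; methoxy for chloro is a different kind of exchange, and no measured pair shows what it does here. With so little to go on, the expectation is a step of a 1.1-fold lower number from compound 2 to compound 3 (0.02 log units; within the scatter) in this assay, that is, nothing beyond the scatter.

Compound 3 is therefore estimated at 25000 nM in this assay, with a range from 9000 nM to 70000 nM.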

Compound 3, concentration for 50% growth inhibition: 2500 nM
Compound 3: middle estimate off by 10-fold (1.00 log units), on the high side; measured number below the stated range.
By their numbers in this assay, from the lowest: compound 3; then compounds 1 and 2 (each within the scatter of the next).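

The earlier halogen exchange had suggested that this place on the ring tolerated change without consequence, but in this assay the methoxy group separates itself clearly from both halogens: 4-methoxybenzyl in place of 4-chlorobenzyl gives an 11-fold lower number from compound 2 to compound 3 (1.02 log units; beyond the scatter), and methoxy in place of fluoro gives a 9.6-fold lower number from compound 1 to compound 3 (0.98 log units; beyond the scatter). The position is therefore not indifferent to what it carries, and both steps reach about the same size, as expected for two halogen compounds that lie within the scatter of each other. The change adds one heavy atom and one hydrogen-bond acceptor, but nothing available accounts for the stronger inhibition of growth.

The compounds shown leave open whether the step goes with the oxygen of the methoxy group or with its carbon, a question that a hydroxyl, a methyl or an ethoxy group at this place would help to settle. For the compounds shown here, they also leave open whether an amine such as dimethylamino would act like methoxy here, and whether the step would hold on any core other than the one these three compounds share.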